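Removing a Methyl Group: Expected Cytotoxicity of Compound 4

The source may report more compounds than this note shows. Statements on the series, on what has been measured and on what is new or still open speak of the compounds shown alone.

Three compounds have been examined in an ADME assay on L02 cells (Homo sapiens) for cytotoxicity, read by MTT assay, with a stated time of 48 h; a lower number here means a stronger inhibitor, a higher number a weaker inhibitor. Compound 1, `O=c1[nH]c2ccccc2cc1-c1nc2cc(F)ccc2[nH]1`, did not reach a measurable number and is recorded only as a limit, > 100000 nM. Compound 2, `Cc1ccc2[nH]c(=O)c(-c3nc4cc(C)c(C)cc4[nH]3)cc2c1`, likewise stopped at a limit, > 100000 nM. Compound 3, `Cc1ccc2[nH]c(=O)c(-c3nc4cc(F)ccc4[nH]3)cc2c1`, also gave only a limit, > 100000 nM. All three therefore sit at the limit of > 100000 nM in this assay, at which 3 of the 3 values shown sit, and no measured number separates them.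

Compound 3 and compound 1 differ in a single place: hydrogen in place of methyl on an aromatic carbon. The step that this change produced, a step that the two limits leave unreadable from compound 3 to compound 1, cannot be read in either direction, since both ends are limits rather than numbers.

Compound 4, `Cc1cc2nc(-c3cc4ccccc4[nH]c3=O)[nH]c2cc1C`, awaits testing in this assay. It is related to compound 2 by the same change, at the same kind of place: hydrogen in place of methyl on an aromatic carbon. How the core of compound 2 differs from the core of compound 3 is not broken down here.

Given the earlier pair, compound 4 is expected to remain at the limit as well, with an estimated value of 150000 nM, plausibly anywhere from 60000 nM to 400000 nM. The step this implies, a step that the limit leaves unreadable from compound 2 to compound 4, is expected to be indistinguishable from no change. This expectation rests on compound 2 at > 100000 nM. It also rests on the unreadable step that the two limits leave unreadable from compound 3 to compound 1, where the identical change left both compounds at the limit.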

Compound 4, half-maximal inhibitory concentration: > 100000 nM
Compound 4 gave a limit, no number (the forecaster's own chance of this, stated with the estimate: 85%); the middle value does not contradict the limit.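

Within the data shown here, compound 4, like compound 2, ended at a limit rather than a number, so the step between them cannot be read and no new step follows from this result. All four compounds share one position: the limit of > 100000 nM in this assay, at which 4 of the 4 values shown sit. With no number among them, they leave open whether hydrogen in place of methyl on an aromatic carbon changes the result in this assay at all, and by how much.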